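Trimethoxyphenyl exchange from compound 3 to compound 4

The source may hold more compounds than are shown below. What is called first, only, known or untested is meant among the compounds shown, and "the series" means these compounds.

In a functional assay on PC-3 cells (Homo sapiens) for cytotoxicity, read by MTT assay, with a stated time of 72 h (on this read-out lower numbers stand for stronger inhibition and higher numbers for weaker inhibition), compound 3 (`COc1cc2ncnc(Nc3ccc(F)c(Cl)c3)c2cc1NC(=O)N/N=C/c1ccc(F)cc1Cl`) gives 25700 nM as its value. Compound 2 (`COc1cc2ncnc(Nc3ccc(F)c(Cl)c3)c2cc1NC(=O)N/N=C/c1ccc(F)cc1`) gives 36500 nM on the same read-out, and compound 1 (`COc1ccc(/C=N/NC(=O)Nc2cc3c(Nc4ccc(F)c(Cl)c4)ncnc3cc2O[C@H]2CCOC2)c(OC)c1OC`) gives 25600 nM there too. The value of compound 3 lies within the scatter of both others, so the three cannot be ranked.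

Compound 4 (`COc1cc2ncnc(Nc3ccc(F)c(Cl)c3)c2cc1NC(=O)N/N=C/c1ccc(OC)c(OC)c1OC`) comes from compound 3 by a single exchange, 2,3,4-trimethoxyphenyl in place of 2-chloro-4-fluorophenyl on a carbon with a double bond to nitrogen, counted as 2,3,4-trimethoxyphenyl in place of 2-chloro-4-fluorophenyl on a carbon with a double bond to nitrogen in full.

Within the data shown here, no measured step covers this exact exchange. The nearest evidence is a smaller change on the same group, a 1.4-fold lower number from compound 2 to compound 3 (0.15 log units; within the scatter) as the measured size, which stays within the scatter. Compound 1 also carries the 2,3,4-trimethoxyphenyl group, and its 25600 nM in this assay falls within the scatter of compound 3. Three compounds are a thin basis, but neither observation points to a real shift in either direction. The expected step is a 1.1-fold higher number from compound 3 to compound 4 (0.04 log units; within the scatter) as an estimate, which means nothing beyond the scatter.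

Compound 4 is estimated at 28000 nM with an expected range from 13000 nM to 60000 nM on this read-out.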

Compound 4, half-maximal inhibitory concentration: 29300 nM
For compound 4 the middle estimate is 1.0-fold (0.02 log units) below the measured one; the measured number falls inside the stated range.
By their numbers in this assay, from the lowest: compounds 1, 3, 4 and 2 (each within the scatter of the next).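

In this assay, the exchange on a carbon with a double bond to nitrogen now has a measured size of its own (a 1.1-fold higher number from compound 3 to compound 4 (0.06 log units; within the scatter)), and 2,3,4-trimethoxyphenyl in place of 4-fluorophenyl at the same place can be read as well (a 1.2-fold lower number from compound 2 to compound 4 (0.10 log units; within the scatter)). Among these compounds, compound 4 also gives the first reading of the other place, with methyl in place of oxolan-3-yl on an oxygen on an aromatic ring (a 1.1-fold higher number from compound 1 to compound 4 (0.06 log units; within the scatter)). All three steps lie within the scatter, so this read-out separates neither the halogenated phenyl groups from 2,3,4-trimethoxyphenyl, despite the hydrogen-bond acceptors the latter brings, nor methyl from oxolan-3-yl.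

Still open, on these data alone, is whether any group at either place gives a step beyond the scatter, for example an amine or a carboxylic acid on the phenyl ring, or a longer chain bearing a morpholine on the oxygen. Nothing available on these compounds explains why the four numbers lie so close together.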